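This account rests on a few compounds, and the source may have more. Where it says the series, first, only, none or still open, it means among the compounds named here.

Working notes on the series. Of the compounds shown here, two on the shared core have been read in a functional assay on KG-1 cells (Homo sapiens) for antiproliferative activity, read by CCK-8 assay, with a stated time of 72 h; on this read-out lower numbers stand for stronger inhibition and higher numbers for weaker inhibition: compound 1 (`Cc1c(-c2c3c(N)n[nH]c(=O)c3nn2-c2ccc(NC(=O)/C=C/CN(C)C)cc2)oc2ccc(Cl)cc12`) and compound 2 (`Cc1ccc2oc(-c3c4c(N)n[nH]c(=O)c4nn3-c3ccc(NC(=O)/C=C/CN(C)C)cc3)c(C)c2c1`). Compound 1 gives 3.7 nM. Compound 2 gives < 0.3 nM, which is a limit of the assay and not a number. Its position is therefore known only as the limit of < 0.3 nM in this assay, at which 1 of the 2 values shown sits.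

Compound 3 (`Cc1c(-c2c3c(N)n[nH]c(=O)c3nn2-c2ccc(NC(=O)/C=C/CN(C)C)cc2)oc2ccc(Br)cc12`) has bromo in place of methyl on an aromatic carbon. Among the measured compounds shown here, one measured step bears on this change, the exchange of chloro for methyl on an aromatic carbon, and it is large: an at least 12-fold lower number from compound 1 to compound 2 (1.09 log units; beyond the scatter). Read in reverse, that step suggests that a halogen in place of the methyl of compound 2 will raise the number in this assay. The closest reference is the chloro compound, compound 1, at 3.7 nM. For the measured compounds named here, no bromo compound has been measured yet, so the range stays wide. The expected change is a higher number, estimated as an at least 6.6-fold higher number from compound 2 to compound 3 (0.82 log units; beyond the scatter). For compound 3 the estimated value is 2 nM, with an expected range from 0.5 nM to 8 nM.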

Compound 3, half-maximal inhibitory concentration in the KG-1 assay: 0.4 nM
For compound 3 the middle estimate is 5.0-fold (0.70 log units) above the measured one; measured number outside the range, below it.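

In the KG-1 assay compound 1 gives 3.7 nM and compound 3 gives 0.4 nM. In the KG-1 assay the exchange of chloro for bromo on this aromatic carbon gives a 9.3-fold lower number from compound 1 to compound 3 (0.97 log units; beyond the scatter), so the weaker reading of compound 1 does not extend to both halogens at this position. In the KG-1 assay the exchange of methyl for bromo shows an at least 1.3-fold higher number from compound 2 to compound 3 (0.12 log units; that floor lies within the scatter), which is only a floor, and in a physicochemical assay for solubility, read by nephelometry, in phosphate buffer, measured as kinetic solubility, at pH 7.4 (on this read-out higher numbers stand for higher solubility and lower numbers for lower solubility), the same exchange shows no change at the digits printed from compound 2 to compound 3 (within the scatter). In the physicochemical assay compound 2 gives 50000 nM and compound 3 gives 50000 nM. The value of compound 2 in the KG-1 assay is a limit of the assay and not a number: the limit of < 0.3 nM in the KG-1 assay, at which 1 of the 3 values shown sits.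

On these data alone, whether methyl and bromo differ at all in the KG-1 assay stays open, as the true size of that step cannot be read from a limit. Also open, as far as these compounds go, is how far the step from chloro to bromo carries over to other groups on this aromatic carbon, such as iodo, a methoxy group, a nitrile or an amine, and whether any of them would shift the reading in the physicochemical assay.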